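The compounds below may be only part of what the source reports. "The series", "measured", "known", "first", "only" and "open" are said of these compounds alone.

- Compound 1 `CC(C)[C@H](NC(=O)COc1cccc2ccccc12)C(=O)N[C@@H](CC(=O)O)C(=O)COC(=O)c1c(Cl)cccc1Cl`: 11500 nM
- Compound 2 `CC(C)[C@H](NC(=O)COc1cccc2ccccc12)C(=O)N[C@@H](CC(=O)O)C(=O)COc1cccc(F)c1`: 12000 nM

In a functional assay with Homo sapiens as the target (a lower number here means a stronger inhibitor, a higher number a weaker inhibitor), compound 2 gives 12000 nM and compound 1 gives 11500 nM. Within the data shown here, these two values lie within the scatter of each other, so compound 2 sits level with the only other measured compound.

The next compound, compound 3 `CC(C)[C@H](NC(=O)COc1cccc2ccccc12)C(=O)N[C@@H](CC(=O)O)C(=O)COc1ccc(F)c(F)c1`, keeps the shared core and changes the aromatic ring of compound 2: fluoro in place of hydrogen on an aromatic carbon. A fluoro takes the place of a hydrogen on an aromatic carbon, ortho to a fluoro group and para to a large group, turning 3-fluorophenyl into 3,4-difluorophenyl.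

Among the measured compounds shown here, only one measured step is available, a 1.0-fold higher number from compound 1 to compound 2 (0.02 log units; within the scatter). For the measured compounds named here, it exchanges a whole group on the oxygen, so it bears on this smaller change only indirectly, and no measured step shows what adding a fluoro does here. With compound 2 at 12000 nM as the anchor, no shift beyond the scatter is expected, and the estimated step is no change at the digits printed from compound 2 to compound 3 (within the scatter). For compound 3 the expected value is 12000 nM, with an estimated range from 5000 nM to 26000 nM.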

Compound 3, half-maximal inhibitory concentration: 16200 nM
Estimate against measurement, compound 3: 1.4-fold (0.13 log units) below; the measured number falls inside the stated range.
By their numbers in this assay, from the lowest: compounds 1, 2 and 3 (each within the scatter of the next).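

In this assay, putting a fluoro on this aromatic carbon, ortho to a fluoro group and para to a large group, gives a 1.4-fold higher number from compound 2 to compound 3 (0.13 log units; within the scatter) and stays within the scatter, so compound 3 sits level with compound 2 and this single-atom addition to the ring does not separate the two. The wider exchange on the oxygen, 3,4-difluorophenyl in place of (2,6-dichlorophenyl)carbonyl, gives a 1.4-fold higher number from compound 1 to compound 3 (0.15 log units; within the scatter) and is also within the scatter, which leaves all three compounds level with one another in this assay. Nothing measured here offers an explanation for how close these numbers lie.

From the compounds shown here alone, whether this position responds to anything other than a fluoro stays open, since a methoxy, an amine or a nitrile on the same aromatic carbon could give a clearly different number or the same one. Going by these compounds, the shared core also stays open, as all three compounds carry it unchanged and so cannot show how much any part of it contributes to the values seen.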